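A few compounds are considered here, and "the series" means these few. Any claim that something is new, unique, unknown or untested is made for them only; others in the source may bear on it.

Among the measured compounds shown here, in an ADME assay on PC-3 cells (Homo sapiens) for cytotoxicity, read by sulforhodamine B assay, with a stated time of 48 h, tested at 10 uM (a higher number here means more inhibition at the concentration tested (going by the name of the read-out), a lower number less inhibition), compound 3 `COc1nc2ccc(Br)cc2cc1C(c1ccccc1)n1cc(-c2ccc(OC(F)(F)F)cc2)nn1` gives 21.6%, the highest of the three numbers measured so far. Compound 2 `CCCCCc1cn(C(c2ccccc2)c2cc3cc(Br)ccc3nc2OC)nn1` gives 11.4%, and compound 1 `CCCCCCc1cn(C(c2ccccc2)c2cc3cc(Br)ccc3nc2OC)nn1` gives 2.32%. Both steps that lead to compound 3 put the aryl group in place of a chain: a number 19.3 percentage points higher from compound 1 to compound 3 (beyond the scatter), and a number 10.2 percentage points higher from compound 2 to compound 3 (beyond the scatter). The step between the two chains, a number 9.1 percentage points higher from compound 1 to compound 2 (within the scatter), stays within the scatter. Compound 4 `COc1nc2ccc(Br)cc2cc1C(c1ccccc1)n1cc(CO)nn1` is not yet measured. The change from compound 3 to compound 4 is hydroxymethyl in place of 4-(trifluoromethoxy)phenyl on an aromatic carbon. For the measured compounds named here, no measured step swaps the aryl group for hydroxymethyl, so none bears on it directly; the nearest guide is the pair of modest rises a number 19.3 percentage points higher from compound 1 to compound 3 (beyond the scatter) and a number 10.2 percentage points higher from compound 2 to compound 3 (beyond the scatter) that accompanied putting the aryl group in place of a chain, which suggests that removing it may give some of that back. The step expected for compound 4 is therefore a fall, estimated as a number 11.6 percentage points lower from compound 3 to compound 4 (beyond the scatter). Compound 4 is estimated at 10%, with a range from 0% to 25%.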

Compound 4, a percentage reported as inhibition, at one concentration (the size of the read-out at that concentration, not a potency): 4.65%
Estimate against measurement, compound 4: 5.4 percentage points above; low and high end bracket the measured number.
By their numbers in this assay, from the lowest: compounds 1, 4 and 2 (each within the scatter of the next); then compound 3.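

In this assay, among the compounds shown here, this is the first direct look at what happens when the aryl group on this carbon of the five-membered aromatic ring gives way to a small group with no ring and a hydrogen-bond donor, and the result is a number 17 percentage points lower from compound 3 to compound 4 (beyond the scatter) in this assay. Set against the chains, hydroxymethyl does not separate from either, with a number 6.8 percentage points lower from compound 2 to compound 4 (within the scatter) and a number 2.3 percentage points higher from compound 1 to compound 4 (within the scatter) both within the scatter, so among these compounds only compound 3 stands apart. No measurement here explains why it does.

A plain phenyl at this carbon would help separate the contribution of the ring from that of its trifluoromethoxy group, while an amine or a carboxylic acid on the same short link would test whether the hydroxy group itself matters. Each number is also a single reading at one concentration, which leaves relative potency open.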